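Ether-linked methylpiperidine in place of morpholinylmethyl

A few compounds are considered here, and "the series" means these few. Any claim that something is new, unique, unknown or untested is made for them only; others in the source may bear on it.

Measured in an assay on isolated protein for inhibition of ubiquitin carboxyl-terminal hydrolase 7 (Homo sapiens), read by fluorescence, with stated times of 30 min and 1 h; on this read-out higher numbers stand for weaker inhibition and lower numbers for stronger inhibition:
compound 1 `O=C([C@H]1Cc2cc(Cl)cc(-c3ccnc4cc(CO)sc34)c2O1)N1CCNCC1` gives 43 nM
compound 2 `Cc1cc(Cl)cc(-c2ccnc3cc(CN4C(=O)C5CC5C4=O)sc23)c1C[C@H]1OCCN[C@@H]1C` gives 1.5 nM
compound 3 `Cc1cc(Cl)cc(-c2ccnc3cc(CN4C(=O)CCC4=O)sc23)c1O[C@H]1CCCNC1` gives 4.6 nM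

Compound 2 holds the lowest number of the three; compound 3 is nearest, and that step is beyond the scatter, as is the wider gap to compound 1. Compound 4 `Cc1cc(Cl)cc(-c2ccnc3cc(CN4C(=O)C5CC5C4=O)sc23)c1O[C@@H]1CCNC[C@@H]1C` keeps the core of compound 2 and differs in one place: (3-methylpiperidin-4-yl)oxy in place of (3-methylmorpholin-2-yl)methyl on an aromatic carbon. Going by the values given here, no measured pair isolates this change; compound 3 shares part of the new arrangement but differs elsewhere, so its value only shows that a low number remains reachable there. For compound 4 a small step toward a higher number is expected, probably within the scatter, giving a 2.0-fold higher number from compound 2 to compound 4 (0.30 log units; within the scatter). The estimate for compound 4 is 3 nM, with a range from 1 nM to 10 nM.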

Compound 4, half-maximal inhibitory concentration: 1.1 nM
For compound 4 the middle estimate is 2.7-fold (0.44 log units) above the measured one; the range from low to high includes it.
By their numbers in this assay, from the lowest: compounds 4 and 2 (each within the scatter of the next); then compound 3; then compound 1.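

In this assay the change of (3-methylmorpholin-2-yl)methyl to (3-methylpiperidin-4-yl)oxy on this aromatic carbon gives a 1.4-fold lower number from compound 2 to compound 4 (0.13 log units; within the scatter) and so leaves the number level. The position therefore accepts either group, with the same atoms joined differently and an oxygen link in place of a carbon link. The compounds shown give no explanation for this.

From the compounds shown here alone, whether the ring nitrogen must remain a secondary amine stays open, as a methylated ring nitrogen or an open aminoethoxy chain on this carbon would tell. Going by these compounds, the contribution of the methyl on the piperidine ring also stays open.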